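From pyridin-4-yl to pyridin-3-yl on the shared core

A few compounds are considered here, and "the series" means these few. Any claim that something is new, unique, unknown or untested is made for them only; others in the source may bear on it.

Measured so far in an ADME assay on BaF3 cells (Mus musculus) for antiproliferative activity, read by CCK-8 assay, with a stated time of 72 h (on this read-out lower numbers stand for stronger inhibition of growth and higher numbers for weaker inhibition of growth), are three compounds:

Compound 1 `CN1CCN(Cc2ccc(NC(=O)CCSc3ccc4c(/C=C/c5ccccn5)n[nH]c4c3)cc2C(F)(F)F)CC1` gives 2480 nM
Compound 2 `Cc1n[nH]c2cc(SCCC(=O)Nc3ccc(CN4CCN(C)CC4)c(C(F)(F)F)c3)ccc12` gives 3900 nM
Compound 3 `CN1CCN(Cc2ccc(NC(=O)CCSc3ccc4c(-c5ccncc5)n[nH]c4c3)cc2C(F)(F)F)CC1` gives 1060 nM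

Compound 3 has the lowest of these three numbers, and both steps that lead to it lie beyond the scatter. They are a 2.3-fold lower number from compound 1 to compound 3 (0.37 log units; beyond the scatter) and a 3.7-fold lower number from compound 2 to compound 3 (0.57 log units; beyond the scatter), and each is modest.

Compound 4 `CN1CCN(Cc2ccc(NC(=O)CCSc3ccc4c(-c5cccnc5)n[nH]c4c3)cc2C(F)(F)F)CC1` has the same atoms as compound 3, joined differently, with pyridin-3-yl in place of pyridin-4-yl on an aromatic carbon in a five-membered aromatic ring with 2 nitrogen.

Among the compounds with values here, no measured step makes this exact exchange. All three measured steps change the group on this same aromatic carbon, however, and the groups they exchange differ far more than the two in question here. Even so, the largest of them is only a 3.7-fold lower number from compound 2 to compound 3 (0.57 log units; beyond the scatter), while a 1.6-fold higher number from compound 1 to compound 2 (0.20 log units; within the scatter) stays within the scatter. A swap between two groups with the same counts is therefore expected to move the number less than those steps did. The estimated change is a 1.2-fold higher number from compound 3 to compound 4 (0.09 log units; within the scatter), which is expected to be no real shift in either direction. For compound 4 the estimated value is 1300 nM, expected to fall between 500 nM and 3300 nM in this assay when measured.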

Compound 4, concentration for 50% growth inhibition: 2650 nM
Estimate against measurement, compound 4: 2.0-fold (0.31 log units) below; measured number inside the range.
By their numbers in this assay, from the lowest: compound 3; then compounds 1, 4 and 2 (each within the scatter of the next).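

The exchange of pyridin-4-yl for pyridin-3-yl on this aromatic carbon, with the same atoms joined differently, is not silent in this assay: it gives a 2.5-fold higher number from compound 3 to compound 4 (0.40 log units; beyond the scatter). The edge of compound 3 over the other groups is lost with that change, since a 1.5-fold lower number from compound 2 to compound 4 (0.17 log units; within the scatter) and a 1.1-fold higher number from compound 1 to compound 4 (0.03 log units; within the scatter) both stay within the scatter, so pyridin-3-yl cannot be told apart here from methyl or from 2-(pyridin-2-yl)ethenyl. Among the four compounds, therefore, having a pyridine ring on this carbon is not enough to separate a compound from the methyl compound, and only the pyridin-4-yl group of compound 3 stands apart from all the others.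

Nothing given here accounts for the difference between the two pyridinyl groups. The compounds shown leave open how pyridin-2-yl, phenyl or a pyrimidine ring would read on this same carbon, and whether the step between pyridin-4-yl and pyridin-3-yl would keep its size if the methylpiperazine at the far end of the molecule gave way to another amine.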